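Swapping the aryl group on the shared core of compound 1

This account rests on a few compounds, and the source may have more. Where it says the series, first, only, none or still open, it means among the compounds named here.

Measured so far:
- compound 1, `COc1cc(C2=NN(C(C)=O)C(c3cccc(OC)c3OC)O2)cc(OC)c1OC`: 35%
- compound 2, `COc1cc(C(=O)N/N=C/c2cccc(C(F)(F)F)c2)cc(OC)c1OC`: 51%
- compound 3, `COc1cc(C(=O)N/N=C/c2ccc(C(F)(F)F)cc2)cc(OC)c1OC`: 59.9%

All three compounds were tested in a functional assay on PC-3 cells (Homo sapiens) for antiproliferative activity, read by MTT assay, tested at 1 uM; a higher number here means a stronger effect of the compound at the concentration tested, a lower number a weaker effect. Among the three numbers compound 1 stands lowest: compound 2 lies above it by a gap beyond the usual scatter, and compound 3 lies further above it, again beyond the scatter. Compounds 2 and 3 share a different linker from compound 1, so their values show only where the trifluoromethyl-bearing analogues on that other linker land, not what the aryl swap does on the core of compound 1.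

The unmeasured compound 4, `COc1cc(C2=NN(C(C)=O)C(c3cccc(C(F)(F)F)c3)O2)cc(OC)c1OC`, keeps the core of compound 1 and changes one group:

3-(trifluoromethyl)phenyl in place of 2,3-dimethoxyphenyl on a saturated ring carbon

Within the data shown here, no step between two measured compounds matches this change. Given that compounds 2 and 3 carry a trifluoromethylphenyl group and give higher numbers than compound 1, the expectation in this assay is a moderate rise from compound 1 to compound 4, rather than none or a fall, though the different core leaves this uncertain. The expected step is a number 10 percentage points higher from compound 1 to compound 4 (within the scatter). Compound 4 is therefore estimated at 45%, with a range from 25% to 65%.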

Compound 4, a percentage reported as inhibition, at one concentration (the size of the read-out at that concentration, not a potency): 30.1%
The estimate for compound 4 lay 14.9 percentage points above the measured number; the measured number falls inside the stated range.
By their numbers in this assay, from the lowest: compounds 4 and 1 (each within the scatter of the next); then compounds 2 and 3 (each within the scatter of the next).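

Among these compounds, on the core of compound 1, this is the first direct reading of the aryl swap: in this assay, 3-(trifluoromethyl)phenyl in place of 2,3-dimethoxyphenyl on the saturated ring carbon gives a number 4.9 percentage points lower from compound 1 to compound 4 (within the scatter) on this position. The two groups have the same number of heavy atoms but differ in what they carry, oxygen in one and fluorine in the other, and this exchange leaves the read-out within the usual scatter, so the position shows no measurable response to this particular change. Nothing measured here explains this result or connects it with the numbers of compound 2 and compound 3, which differ from compound 4 in more than one place.

As far as these compounds go, it remains open whether this position would respond to a group of another kind, such as a basic amine like piperidine or a carboxylic acid on the aryl ring. The compounds shown also leave open whether changing the acetyl group on the ring nitrogen to a longer chain, such as butanoyl, would move the number beyond the scatter.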